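This account rests on a few compounds, and the source may have more. Where it says the series, first, only, none or still open, it means among the compounds named here.

Of the compounds shown here, three on a shared core have been read in a functional assay on HCT-116 cells (Homo sapiens) for inhibition; on this read-out lower numbers stand for stronger inhibition and higher numbers for weaker inhibition. Compound 1 `COCCOc1cc(/C=C/c2ccc3ccccc3c2)ccc1OC` gives > 5000 nM, which is a limit and not a number. Within the data shown here, compound 2 `Oc1ccc(/C=C/c2ccc3ccccc3c2)cc1` gives the only actual number, 4060 nM. Compound 3 `COc1ccc(/C=C/c2ccc3ccccc3c2)cc1` gives > 5000 nM, which is also a limit. Compound 3 thus stands at the limit of > 5000 nM in this assay, at which 2 of the 3 values shown sit.

Compound 4 `COc1ccc(/C=C/c2ccc3ccccc3c2)cc1F` differs from compound 3 by one change: fluoro in place of hydrogen on an aromatic carbon, ortho to a methoxy group and meta to a large group. Among the measured compounds shown here, no measured step involves fluoro, so the evidence is only indirect. Placing methyl in place of hydrogen on an oxygen gave an at least 1.2-fold higher number from compound 2 to compound 3 (0.09 log units; that floor lies within the scatter). Placing hydrogen in place of 2-methoxyethoxy gave a step that the two limits leave unreadable from compound 1 to compound 3. For the measured compounds named here, with the one readable step inside the scatter, no step beyond the scatter is expected in this assay, and no direction can be favoured. The expected change is a number no higher from compound 3 to compound 4 (the limit leaves the size open). For compound 4 the estimated value is 5000 nM, with an expected range from 1800 nM to 10000 nM.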

Compound 4, half-maximal inhibitory concentration: > 5000 nM
Compound 4: no number, only a limit (the forecaster's own chance of this, stated with the estimate: 60%); the middle value sits exactly at the limit.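

Compound 4, like compound 1 and compound 3, gives a limit and not a number, so neither of its steps from those two compounds can be read. The compounds shown leave open whether fluoro in place of hydrogen changes the result in this assay at all.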